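Series notes: methyl removed from an aromatic oxygen

The source may report more compounds than this note shows. Statements on the series, on what has been measured and on what is new or still open speak of the compounds shown alone.

Measured in a functional assay on HaCaT cells (Homo sapiens), read by fluorescence and BrdU incorporation, with a stated time of 48 h, tested at 10 uM (on this read-out higher numbers stand for a weaker effect at the one concentration tested and lower numbers for a stronger effect), so far:
compound 1 `COc1cccc(/C=C/C(=O)c2c(OC)cc(OC)cc2OC)c1` — 19%
compound 2 `COc1cc(OC)c(C(=O)/C=C/c2ccccc2)c(OC)c1` — 18%
compound 3 `COc1cc(OC)c(C(=O)/C=C/c2ccc(Br)cc2)c(OC)c1` — 24%

Compound 1 stands second highest of the three numbers. Its nearest neighbour is compound 2, with a number 1 percentage points lower from compound 1 to compound 2 (within the scatter); its furthest is compound 3, with a number 5 percentage points higher from compound 1 to compound 3 (within the scatter). The remaining pair, compound 2 and compound 3, shows a number 6 percentage points higher from compound 2 to compound 3 (within the scatter). Every step in this set lies within the scatter, so the three compounds cannot be ranked against one another in this assay.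

Compound 4 `COc1cccc(/C=C/C(=O)c2c(O)cc(OC)cc2OC)c1` is the next compound. It differs from compound 1 by hydrogen in place of methyl on an oxygen on an aromatic ring. Going by the values given here, none of the measured steps touches the place where this change sits: the step from compound 1 to compound 2 alters an oxygen-bearing group, but on the other ring, and the two steps to compound 3 concern a bromo substituent. All of them are within the scatter. Among the compounds with values here, with no measured step bearing on it and nothing in the set moving beyond the scatter, the expectation for compound 4 is a step of about a number 1 percentage points higher from compound 1 to compound 4 (within the scatter) in this assay, that is, no step beyond the scatter. The estimate for compound 4 is 20%, with a range from 8% to 36%.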

Compound 4, a percentage reported as activity, at one concentration (the size of the read-out at that concentration, not a potency): 49%
For compound 4 the middle estimate is 29 percentage points below the measured one, outside the stated range (above it).
By their numbers in this assay, from the lowest: compounds 2, 1 and 3 (each within the scatter of the next); then compound 4.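

In this assay, going by these compounds alone, hydrogen in place of methyl on an oxygen on an aromatic ring gives a number 30 percentage points higher from compound 1 to compound 4 (beyond the scatter) and so a weaker effect at the one concentration tested, the first single change to move the read-out beyond the scatter. The other single changes, seen in a number 1 percentage points lower from compound 1 to compound 2 (within the scatter) and a number 6 percentage points higher from compound 2 to compound 3 (within the scatter), stay within the scatter, so this oxygen is the only place shown so far where the read-out responds to a change. Nothing at hand explains this step.

The compounds shown leave open whether the step follows from the free hydroxy itself or from the loss of the methyl, and a longer chain such as ethoxy, an acetyl group or an amine in this place would be needed to separate the two. As far as these compounds go, it also remains open whether methoxy to hydroxy gives a step of similar size on the cores of compound 2 and compound 3, which carry no hydroxy.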